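Compound 4: chloro removed from the core of compound 2

A few compounds are considered here, and "the series" means these few. Any claim that something is new, unique, unknown or untested is made for them only; others in the source may bear on it.

Working notes on the series. Compound 1 `Cc1cc(C)cc(Oc2nc(NCCn3ccc(=O)[nH]c3=O)ncc2Cl)c1` is tested in an ADME assay on MT4 cells (Homo sapiens) for cytotoxicity, read by MTT assay, with a stated time of 5 days; a lower number here means that less compound is tolerated, a higher number that more compound is tolerated. In this assay compound 1 reaches only the limit > 322000 nM, and the limit of > 322000 nM in this assay, at which 1 of the 3 values shown sits, marks this. Compound 2 `Cc1cc(C)cc(Oc2cc(Cl)nc(NCCn3ccc(=O)[nH]c3=O)n2)c1` carries the chloro at a different ring position. In this assay compound 2 gives only the limit > 56400 nM; the limit of > 56400 nM in this assay, at which 1 of the 3 values shown sits, records it. Within the data shown here, compound 3 `Cc1cc(C)c(Oc2cc(Cl)nc(NCCn3ccc(=O)[nH]c3=O)n2)c(C)c1` is the one compound of the three with a number in this assay, where compound 3 gives 44100 nM. Among the measured compounds shown here, the one measured step, an at least 1.2-fold lower number from compound 2 to compound 3 (0.10 log units; that floor lies within the scatter), concerns the phenoxy group alone and its floor lies within the scatter.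

Compound 2 therefore stands on a limit, not on a number, with compound 1 likewise at a limit and compound 3 alone on a figure close to that limit.

Compound 4 `Cc1cc(C)cc(Oc2ccnc(NCCn3ccc(=O)[nH]c3=O)n2)c1` differs from compound 2 by hydrogen in place of chloro on an aromatic carbon. For the measured compounds named here, no measured step touches this position, so nothing in the data bears on the change; the only step recorded runs between compound 2 and compound 3 and alters a different group. The expectation is therefore no step beyond the scatter in this assay, a step that the limit leaves unreadable from compound 2 to compound 4, with a fair chance that only a limit is reported again. Compound 4 is estimated at 80000 nM, within a range of 40000 nM to 300000 nM.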

Compound 4, half-maximal cytotoxic concentration: 74800 nM
Estimate against measurement, compound 4: 1.1-fold (0.03 log units) above; measured number inside the range.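

In this assay compound 4, with hydrogen in place of chloro on the aromatic carbon next to the ring nitrogen, gives 74800 nM, so this 3,5-dimethylphenoxy compound now has a figure rather than a limit. Compound 2, the direct chloro partner, stands only at a limit, so the step at this position cannot be read: the limit of > 56400 nM in this assay, at which 1 of the 4 values shown sits. Among these compounds, the one readable comparison is with the chloro at the other ring position, an at least 4.3-fold lower number from compound 1 to compound 4 (0.63 log units; beyond the scatter), and it is a floor set by a limit, so it shows that hydrogen in place of chloro there registers beyond the scatter without giving the true size of the change.

From the compounds shown here alone, whether chloro at the position next to the ring nitrogen raises, lowers or leaves unchanged the tolerated concentration stays open, as compound 2 has no figure to set against compound 4. Also open, going by these compounds, is how this aromatic carbon would respond to a different group, such as a methyl, a methoxy or an amine, and whether the 2,4,6-trimethylphenyl group of compound 3 would behave in the same way on the core without chloro.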